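Ethynyl-to-vinyl change on the bis-aryl diene series

This account rests on a few compounds, and the source may have more. Where it says the series, first, only, none or still open, it means among the compounds named here.

Compound 1 `C#CCCCC=C(c1cc(Br)c(OC)c(C(=O)OC)c1)c1cc(Br)c(OC)c(C(=O)OC)c1` and compound 2 `C#CCCCC=C(c1cc(Cl)c(OC)c(C(=O)OC)c1)c1cc(Cl)c(OC)c(C(=O)OC)c1` share a common layout; the difference between their two cores is not broken down here. In an ADME assay on the whole organism (plasma) for metabolic stability, with Rattus norvegicus as the target (a higher number here means that the compound lasts longer, a lower number that the compound disappears faster), compound 1 gives 0.315 h, and in the same assay compound 2 gives 0.343 h; these two numbers lie within the scatter of each other. Compound 3 `C=CCCCC=C(c1cc(Br)c(OC)c(C(=O)OC)c1)c1cc(Br)c(OC)c(C(=O)OC)c1` is compound 1 with vinyl in place of ethynyl on a saturated chain carbon, three bonds along the chain from a double-bonded chain carbon. In this assay compound 3 gives 0.975 h, which is a 3.1-fold higher number from compound 1 to compound 3 (0.49 log units; beyond the scatter). Compound 4 `C=CCCCC=C(c1cc(Cl)c(OC)c(C(=O)OC)c1)c1cc(Cl)c(OC)c(C(=O)OC)c1` carries the corresponding change on the core of compound 2, namely (vinyl in place of ethynyl on a saturated chain carbon, three bonds along the chain from a double-bonded chain carbon); the place of the change reads the same in both pairs, so it is the same change, seen twice in the series. Compound 4 has not yet been measured in this assay. Among the compounds with values here, only one instance of this change carries a number, so any expectation rests on a single step. The step is expected to be a 2.9-fold higher number from compound 2 to compound 4 (0.46 log units; beyond the scatter). Within the data shown here, this rests on the one measured instance, a 3.1-fold higher number from compound 1 to compound 3 (0.49 log units; beyond the scatter), and on compound 2 starting from 0.343 h. Compound 4 is estimated at 1 h in this assay, with a range from 0.5 h to 2 h.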

Compound 4, half-life: 0.655 h
For compound 4 the middle estimate is 1.5-fold (0.18 log units) above the measured one; the range from low to high includes it.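

In this assay, vinyl in place of ethynyl on the core of compound 2 gives a 1.9-fold higher number from compound 2 to compound 4 (0.28 log units; within the scatter), in the same direction as the first instance, and the size of the two steps cannot be told apart: the same change on two cores in this assay, a 3.1-fold higher number (0.49 log units; beyond the scatter) from compound 1 to compound 3 and a 1.9-fold higher number (0.28 log units; within the scatter) from compound 2 to compound 4, 1.6-fold (0.21 log units) apart, within the scatter of two such steps

The change therefore carries between these two cores in direction, and the data fit one shared step. This does not fix the size of that step, since the step on the core of compound 2 lies within the scatter when taken alone, and two cores give no rule for any other core in the series.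

The compounds shown leave open whether the step holds on a core carrying a carboxylic acid in place of the methyl ester. They also leave open what a fully saturated chain end, such as an ethyl group in place of vinyl, or a longer chain would give in this assay.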